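A few compounds are considered here, and "the series" means these few. Any claim that something is new, unique, unknown or untested is made for them only; others in the source may bear on it.

Of the compounds shown here, three sharing one core have been tested in an assay on membranes from HEK293 cells for displacement of a labelled ligand from adenosine receptor A2b (Homo sapiens), read by scintillation counting, with a stated time of 30 min, tested at 1 uM; on this read-out lower numbers stand for less inhibition and higher numbers for more inhibition at the one concentration tested (going by the name of the read-out). Compound 1 `CCCOC(=O)C1=C(C)N(C)C(=O)NC1c1ccco1` gives 23%, compound 2 `CC1=C(C(=O)OC(C)(C)C)C(c2ccco2)NC(=O)N1C` gives 26%, and compound 3 `CC1=C(C(=O)OCc2ccccc2)C(c2ccco2)NC(=O)N1C` gives 41%, the highest of the three. Every measured step changes the group on the oxygen next to a carbonyl group: a number 3 percentage points higher from compound 1 to compound 2 (within the scatter), a number 18 percentage points higher from compound 1 to compound 3 (beyond the scatter) and a number 15 percentage points higher from compound 2 to compound 3 (beyond the scatter). Compound 4 `CC1=C(C(=O)OCc2ccccc2)C(c2cccs2)NC(=O)N1C` differs from compound 3 in another place: thiophen-2-yl in place of furan-2-yl on a saturated ring carbon. Among the compounds with values here, none of the measured steps touches this ring, so nothing here speaks for a move beyond the scatter, and the expected step of a number 3 percentage points higher from compound 3 to compound 4 (within the scatter) is therefore small. Compound 4 is estimated to give 44%, with a range from 25% to 63%.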

Compound 4, a percentage reported as inhibition, at one concentration (the size of the read-out at that concentration, not a potency): 50%
Compound 4: the middle estimate sits 6 percentage points below what was measured, and the stated range covers the measured number.
By their numbers in this assay, from the lowest: compounds 1 and 2 (each within the scatter of the next); then compounds 3 and 4 (each within the scatter of the next).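

Within the data shown here, at the saturated ring carbon, a place none of the earlier steps touched, thiophen-2-yl in place of furan-2-yl gives a number 9 percentage points higher from compound 3 to compound 4 (within the scatter) in this assay on top of the benzyl group. Sulfur can thus replace oxygen in this five-membered aromatic ring with no change that stands clear of the usual scatter. No measurement is at hand that could explain this result.

As far as these compounds go, whether a phenyl, a pyridin-3-yl or a saturated cyclohexyl group at this carbon would move the number beyond the scatter stays open.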